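The source may report more compounds than this note shows. Statements on the series, on what has been measured and on what is new or still open speak of the compounds shown alone.

Measured so far in a functional assay on SF-539 cells (Homo sapiens) for inhibition, read by sulforhodamine B assay, with a stated time of 48 h; on this read-out lower numbers stand for higher toxicity in this test and higher numbers for lower toxicity in this test:

compound 1, `O=C(Nc1cccc(-n2cc(-c3ccncc3)c(-c3ccc(Cl)c(O)c3)n2)c1)Nc1ccc(Cl)c(Cl)c1`, > 32500 nM
compound 2, `COc1cc(-c2nn(-c3cccc(NC(=O)c4ccc(Cl)c(C(F)(F)F)c4)c3)cc2-c2ccncc2)ccc1Cl`, > 32500 nM

Both numbers are limits of this assay, not measured values. For compound 1, `O=C(Nc1cccc(-n2cc(-c3ccncc3)c(-c3ccc(Cl)c(O)c3)n2)c1)Nc1ccc(Cl)c(Cl)c1`, this assay reports only the limit > 32500 nM. For compound 2, `COc1cc(-c2nn(-c3cccc(NC(=O)c4ccc(Cl)c(C(F)(F)F)c4)c3)cc2-c2ccncc2)ccc1Cl`, this assay likewise reports only the limit > 32500 nM. Compound 2 therefore stands at the edge of what this assay resolves, and it shares that position with the only other compound shown, as the limit of > 32500 nM in this assay, at which 2 of the 2 values shown sit, records; no ranking between the two can be drawn from this.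

Compound 3, `COc1cc(-c2nn(-c3cccc(NC(=O)c4cccc(C(F)(F)F)c4)c3)cc2-c2ccncc2)ccc1Cl`, is not yet measured. It differs from compound 2 in one place: hydrogen in place of chloro on an aromatic carbon. Going by the values given here, the change is small, a single heavy atom leaving an aromatic ring without altering the amide or the shared core, and no measured step between related compounds exists to calibrate it.

Given that compound 2 sits at the limit, the step from compound 2 to compound 3 is expected to be a step that the limit leaves unreadable from compound 2 to compound 3, with no change beyond the scatter resolved. Compound 3 is thus expected to give about 40000 nM in this assay, in a range from 12000 nM to 130000 nM, and most likely again only a limit rather than a number.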

Compound 3, concentration lethal to 50% of the cells: > 50000 nM
Compound 3 ended at the assay's limit (the forecaster's own chance of this, stated with the estimate: 80%); middle value at least 1.2-fold (0.09 log units) from the limit.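

In this assay compound 2 and compound 3 both stand at limits, and the step between them, hydrogen in place of chloro, cannot be read. The compounds shown leave open whether the change from 4-chloro-3-(trifluoromethyl)phenyl to 3-(trifluoromethyl)phenyl shifts this read-out at all, and whether any compound in the series gives a true number here.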